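This account rests on a few compounds, and the source may have more. Where it says the series, first, only, none or still open, it means among the compounds named here.

In a functional assay on MV4-11 cells (Homo sapiens) for antiproliferative activity, read by luminescence and CellTiter-Glo, with a stated time of 72 h (on this read-out higher numbers stand for weaker inhibition and lower numbers for stronger inhibition), compound 3 `CNc1cc(-c2ccc3cnn(Cc4ccc(F)c(F)c4)c3c2)cn(C)c1=O` gives 320 nM and stands within the scatter of compound 2 `CNc1cc(-c2ccc3cnn(Cc4cc(OC)cc(OC)c4)c3c2)cn(C)c1=O` at 190 nM and far from compound 1 `CNc1cc(-c2ccc3cnn(Cc4ccc(C)cc4)c3c2)cn(C)c1=O` at 3280 nM in this small set. Compound 4 `CNc1cc(-c2ccc3cnn(Cc4ccc(F)c([N+](=O)[O-])c4)c3c2)cn(C)c1=O` keeps the shared core and alters one group: nitro in place of fluoro on an aromatic carbon describes nitro in place of fluoro on an aromatic carbon, ortho to a fluoro group and meta to a large group, so that 3,4-difluorophenyl becomes 4-fluoro-3-nitrophenyl. Two measured steps are large, a 10-fold lower number from compound 1 to compound 3 (1.01 log units; beyond the scatter) and a 17-fold lower number from compound 1 to compound 2 (1.24 log units; beyond the scatter), but both leave 4-methylphenyl, a group absent from compound 4, so they offer little guidance here. The nearer guide is a 1.7-fold higher number from compound 2 to compound 3 (0.23 log units; within the scatter), a swap between two other ring patterns that stays within the scatter. For the measured compounds named here, no measured compound carries a nitro, so the direction is only weakly founded. The expected change is small, with an estimated 1.3-fold higher number from compound 3 to compound 4 (0.10 log units; within the scatter) that probably stays within the scatter. Compound 4 is estimated at 400 nM with an expected range from 130 nM to 1300 nM.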

Compound 4, half-maximal inhibitory concentration: 130 nM
Estimate against measurement, compound 4: 3.1-fold (0.49 log units) above; low and high end bracket the measured number.
By their numbers in this assay, from the lowest: compounds 4, 2 and 3 (each within the scatter of the next, the first and the last beyond it); then compound 1.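

In this assay the swap of fluoro for nitro on an aromatic carbon, ortho to a fluoro group and meta to a large group, gives a 2.5-fold lower number from compound 3 to compound 4 (0.39 log units; beyond the scatter) and so shows that this position accepts the larger group with a lower number, not merely an unchanged one. Against the 3,5-dimethoxyphenyl compound the result is a 1.5-fold lower number from compound 2 to compound 4 (0.16 log units; within the scatter) and stays within the scatter, whereas a 25-fold lower number from compound 1 to compound 4 (1.40 log units; beyond the scatter) is a large step and puts the 4-fluoro-3-nitrophenyl compound far from the 4-methylphenyl compound. Nothing available accounts for the effect of the nitro group on this number.

From the compounds shown here alone, how an amine or a carboxylic acid at this position would read in this assay stays open. Also open, going by these compounds, is whether nitro would keep this number without the neighbouring fluoro group on the ring.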